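The compounds below may be only part of what the source reports. "The series", "measured", "known", "first", "only" and "open" are said of these compounds alone.

Of the compounds shown here, three have been measured in an assay on isolated protein for inhibition of Rho-associated protein kinase 1 (Homo sapiens), read by scintillation counting, radiometric assay and 33P incorporation, with a stated time of 40 min, in the presence of a further agent that is not named here; on this read-out higher numbers stand for weaker inhibition and lower numbers for stronger inhibition. Compound 1 `CC(=O)c1ccc(OCC(=O)Nc2cccc(NC(=O)c3ccc(N(C)C)cc3)c2)cc1F` gives 445 nM. Compound 2 `CN(C)c1ccc(C(=O)Nc2cccc(NC(=O)COc3ccc4occc(=O)c4c3)c2)cc1` reaches only the limit of > 10000 nM, which is a limit of the measurement and not a number. Compound 3 `CC(=O)Nc1cccc(NC(=O)COc2ccc3c(=O)ccoc3c2)c1` gives 2500 nM, the higher of the two numbers given; compound 1 lies below it by a gap beyond the usual scatter.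

One step between measured compounds has been counted: an at least 22-fold higher number from compound 1 to compound 2 (1.35 log units; beyond the scatter). That step sits at the ether oxygen, on the far side of the shared core, and its size is capped by the limit of > 10000 nM in this assay, at which 1 of the 3 values shown sits.

Compound 4 `CCOc1ccc(C(=O)Nc2cccc(NC(=O)COc3ccc4c(=O)ccoc4c3)c2)cc1` differs from compound 3 by 4-ethoxyphenyl in place of methyl on a carbonyl carbon. For the measured compounds named here, no measured step covers this change at the carbonyl carbon, so the expectation rests on what the neighbouring values show. Compound 2, which carries another six-membered aromatic group of carbon only at the same carbonyl carbon, also bears the chromone-containing group, and its value in this assay is a limit. Compound 3 gives 2500 nM with methyl there. Compound 4 is therefore expected to weaken rather than strengthen, with an estimated 6000 nM, between 1500 nM and 20000 nM. That expectation amounts to a step of a 2.4-fold higher number from compound 3 to compound 4 (0.38 log units; beyond the scatter).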

Compound 4, half-maximal inhibitory concentration: 17 nM
For compound 4 the middle estimate is 350-fold (2.55 log units) above the measured one, and the stated range ends above it.
By their numbers in this assay, from the lowest: compound 4; then compound 1; then compound 3. At a limit, above all of these: compound 2.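

In this assay, the carbonyl carbon whose other neighbour is the amide-type nitrogen proves to be a place where a single change can move the number a long way: a 150-fold lower number from compound 3 to compound 4 (2.17 log units; beyond the scatter). For the compounds shown here, the earlier step concerned only the group on the ether oxygen, so this is the only measured evidence at this carbonyl carbon, and it shows that 4-ethoxyphenyl, with its nine heavy atoms and aromatic ring, is far from harmful here in a compound that keeps the rest of compound 3 unchanged. Nothing measured here explains why this change has such a large effect.

The change brought in an aromatic ring and an ethoxy group together, so the compounds shown leave open how much of the step belongs to each, a question that a plain phenyl group at the same carbonyl carbon would help to separate. They also leave open how the number responds to other groups on that ring, such as a longer chain like butoxy, an amine or a carboxylic acid in place of the ethoxy group.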